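Carbonyl substituent changes on the piperidine-bearing amide of the series

The source may report more compounds than this note shows. Statements on the series, on what has been measured and on what is new or still open speak of the compounds shown alone.

Measured so far in an ADME assay on Caco-2 cells (Homo sapiens) for permeability, in the apical to basolateral direction; on this read-out higher numbers stand for higher permeability and lower numbers for lower permeability:
compound 1, `Cn1cnc(S(=O)(=O)N2CCC(CN(C3Cc4cc(C#N)ccc4N(Cc4cncn4C)C3)S(=O)(=O)c3ccccn3)CC2)c1`, gives 0.1 10^-6 cm/s
compound 2, `Cn1cncc1CN1CC(N(CC2CCN(C(=O)N3CCCCC3)CC2)S(=O)(=O)c2ccccn2)Cc2cc(C#N)ccc21`, gives 0.6 10^-6 cm/s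
compound 3, `Cn1cncc1CN1CC(N(CC2CCN(C(=O)C3CC3)CC2)S(=O)(=O)c2ccccn2)Cc2cc(C#N)ccc21`, gives 0.5 10^-6 cm/s

Compound 3 stands second highest of the measured numbers in this assay ; its nearest neighbour is compound 2, which lies within the scatter of it, and its furthest is compound 1, reached by a 5.0-fold higher number from compound 1 to compound 3 (0.70 log units; beyond the scatter).

Compound 4, `Cn1cncc1CN1CC(N(CC2CCN(C(=O)OCc3ccccc3)CC2)S(=O)(=O)c2ccccn2)Cc2cc(C#N)ccc21`, differs from compound 3 by benzyloxy in place of cyclopropyl on a carbonyl carbon. Among the compounds with values here, the only step that touches the same carbonyl carbon is a 1.2-fold lower number from compound 2 to compound 3 (0.08 log units; within the scatter), which stayed within the scatter. The larger steps, a 6.0-fold higher number from compound 1 to compound 2 (0.78 log units; beyond the scatter) and a 5.0-fold higher number from compound 1 to compound 3 (0.70 log units; beyond the scatter), concern the exchange of the sulfonyl for a carbonyl and do not bear on this change. No step beyond the scatter is therefore expected; the estimated step is a 1.2-fold higher number from compound 3 to compound 4 (0.08 log units; within the scatter), giving for compound 4 an expected value of 0.6 10^-6 cm/s, within 0.3 10^-6 cm/s to 1.3 10^-6 cm/s.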

Compound 4, apparent permeability: 1 10^-6 cm/s
Beside the measured number, compound 4's estimate is 1.7-fold (0.22 log units) below it, within the range that was stated.
By their numbers in this assay, from the lowest: compound 1; then compounds 3, 2 and 4 (each within the scatter of the next).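

On the carbonyl carbon, benzyloxy, with its six-membered aromatic ring and one hydrogen-bond acceptor, reads no differently in this assay from cyclopropyl (a 2.0-fold higher number from compound 3 to compound 4 (0.30 log units; within the scatter)) or piperidin-1-yl (a 1.7-fold higher number from compound 2 to compound 4 (0.22 log units; within the scatter)). Benzyloxycarbonyl also stands clear of the (1-methyl-1H-imidazol-4-yl)sulfonyl group (a 10-fold higher number from compound 1 to compound 4 (1.00 log units; beyond the scatter)). No available evidence accounts for these numbers.

Still open, from the compounds shown here alone, is whether an amine or a carboxylic acid carried on the benzyl ring would stay within the scatter of compound 4. Going by these compounds, a longer chain between the oxygen and the aromatic ring also remains untested here.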